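Adding one methoxy group to compound 3

This account rests on a few compounds, and the source may have more. Where it says the series, first, only, none or still open, it means among the compounds named here.

Compound 1 `COc1cc(C=C(C(=O)/C=C/c2cccc(OC)c2OC)C(=O)/C=C/c2cccc(OC)c2OC)ccc1O` gives 130 nM
Compound 2 `COc1cccc(/C=C/C(=O)C(=Cc2cc(OC)c(OC)c(OC)c2)C(=O)/C=C/c2cccc(OC)c2OC)c1OC` gives 230 nM
Compound 3 `COc1cccc(C=C(C(=O)/C=C/c2cccc(OC)c2OC)C(=O)/C=C/c2cccc(OC)c2OC)c1OC` gives 320 nM
Compound 4 `COc1cccc(/C=C/C(=O)C(=Cc2ccc(OC)c(OC)c2OC)C(=O)/C=C/c2cccc(OC)c2OC)c1OC` has not yet been measured

All of these numbers come from a functional assay on A549 cells (Homo sapiens) for antiproliferative activity, read by sulforhodamine B assay, with a stated time of 48 h (on this read-out lower numbers stand for stronger inhibition and higher numbers for weaker inhibition), and can be compared directly. Compound 3 sits within the scatter of compound 2, and the only clear gap involving it is a 2.5-fold higher number from compound 1 to compound 3 (0.39 log units; beyond the scatter) and that gap is small.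

Compound 4 keeps the rest of compound 3 and makes one change, described as methoxy in place of hydrogen on an aromatic carbon and amounting to methoxy in place of hydrogen on an aromatic carbon. This turns 2,3-dimethoxyphenyl into 2,3,4-trimethoxyphenyl.

Among the measured compounds shown here, no measured pair makes exactly this change. The closest guide is a 1.4-fold higher number from compound 2 to compound 3 (0.14 log units; within the scatter) and that step stays within the scatter. It compares a trimethoxyphenyl group with the 2,3-dimethoxyphenyl group. The step of a 2.5-fold higher number from compound 1 to compound 3 (0.39 log units; beyond the scatter) removes a 4-hydroxy-3-methoxyphenyl group, which compound 4 does not carry, so it says little here. No step beyond the scatter is therefore expected in this assay and no direction can be called with confidence.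

The estimated change is a 1.2-fold lower number from compound 3 to compound 4 (0.07 log units; within the scatter) and this is well within what repeat measurements could show. The expected value for compound 4 is 270 nM with an estimated range from 120 nM to 600 nM for a typical measurement.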

Compound 4, half-maximal inhibitory concentration: 260 nM
Estimate against measurement, compound 4: 1.0-fold (0.02 log units) above, and the stated range covers the measured number.
By their numbers in this assay, from the lowest: compounds 1, 2, 4 and 3 (each within the scatter of the next, the first and the last beyond it).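

In this assay, placing a methoxy group on the aromatic carbon para to the large group, ortho to one methoxy group and meta to another, gives a 1.2-fold lower number from compound 3 to compound 4 (0.09 log units; within the scatter) and so this position accepts the extra group with no change that can be told from the scatter. The new compound also shows that two arrangements of three methoxy groups cannot be separated here: the swap of 3,4,5-trimethoxyphenyl for 2,3,4-trimethoxyphenyl gives a 1.1-fold higher number from compound 2 to compound 4 (0.05 log units; within the scatter) and is equally small. Among the compounds shown here, replacing 4-hydroxy-3-methoxyphenyl with 2,3,4-trimethoxyphenyl gives a 2.0-fold higher number from compound 1 to compound 4 (0.30 log units; within the scatter) and stays within the scatter, whereas the swap to 2,3-dimethoxyphenyl gives a 2.5-fold higher number from compound 1 to compound 3 (0.39 log units; beyond the scatter) and lies just beyond it, so only that last pair shows a gap, and a modest one.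

On these data alone, these compounds carry only methoxy and hydroxy groups on this ring, so the effect of a dimethylamino group or a carboxylic acid at the same position remains open. Nothing further is available to explain why these numbers lie so close together.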